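Aryl exchange on the carbon double-bonded to nitrogen

This account rests on a few compounds, and the source may have more. Where it says the series, first, only, none or still open, it means among the compounds named here.

Measured in a functional assay on MDA-MB-231 cells (Homo sapiens) for cytotoxicity, read by MTT assay, with a stated time of 48 h; a lower number here means a stronger inhibitor, a higher number a weaker inhibitor:
compound 1 `COc1ccc(C2=NOC(COc3ccc(-c4nnnn4-c4cc(OC)c(OC)c(OC)c4)cc3N)C2)cc1N` gives 3000 nM
compound 2 `COc1ccc(C2=NOC(COc3ccc(-c4nnnn4-c4cc(OC)c(OC)c(OC)c4)cc3N)C2)cc1OC` gives 3570 nM
compound 3 `COc1ccc(C2=NOC(COc3ccc(-c4nnnn4-c4cc(OC)c(OC)c(OC)c4)cc3N)C2)cc1O` gives 3380 nM

Compound 2 sits at the top of these three numbers, but only by a 1.2-fold higher number from compound 1 to compound 2 (0.08 log units; within the scatter) and by a 1.1-fold lower number from compound 2 to compound 3 (0.02 log units; within the scatter), so the three compounds are not separable in this assay. Compound 4 `COc1cc(-n2nnnc2-c2ccc(OCC3CC(c4cccc(Cl)c4)=NO3)c(N)c2)cc(OC)c1OC` is the next step from compound 2: 3-chlorophenyl in place of 3,4-dimethoxyphenyl on a carbon with a double bond to nitrogen. The three measured steps all touch the ring at this same place, and all three stayed within the scatter: a 1.2-fold higher number from compound 1 to compound 2 (0.08 log units; within the scatter), a 1.1-fold higher number from compound 1 to compound 3 (0.05 log units; within the scatter), a 1.1-fold lower number from compound 2 to compound 3 (0.02 log units; within the scatter). None of them exchanges the whole ring, so the change to compound 4 is larger than anything yet measured here, and the evidence for it is indirect. Given that the substituent changes at this ring left the number flat, no step beyond the scatter is expected for compound 4, that is, a 1.0-fold lower number from compound 2 to compound 4 (0.01 log units; within the scatter). Compound 4 is therefore estimated at 3500 nM, with a range of 1500 nM to 8000 nM.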

Compound 4, half-maximal inhibitory concentration: 2180 nM
Compound 4: the middle estimate sits 1.6-fold (0.21 log units) above what was measured; the measured number falls inside the stated range.
By their numbers in this assay, from the lowest: compounds 4, 1, 3 and 2 (each within the scatter of the next).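

In this assay, exchanging the whole aryl group on the carbon with a double bond to nitrogen gives a 1.6-fold lower number from compound 2 to compound 4 (0.21 log units; within the scatter), a 1.6-fold lower number from compound 3 to compound 4 (0.19 log units; within the scatter) and a 1.4-fold lower number from compound 1 to compound 4 (0.14 log units; within the scatter). Within the data shown here, the earlier compounds varied only one substituent on this ring, whereas compound 4 shows that even a 3-chlorophenyl group, with no methoxy group on the ring, does not move the number beyond the scatter at this position. No measurement bearing on the reason for this result is available here.

Going by these compounds, whether an unsubstituted phenyl, a pyridyl ring or a phenyl carrying a carboxylic acid would also stay within the scatter remains open. On these data alone, the rest of the core is the same in all four compounds, so it is also open whether this exchange would behave alike with a different group elsewhere on the core.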